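Solubility Along a Quinoline Series: From Compound 2 to Compound 3

This account rests on a few compounds, and the source may have more. Where it says the series, first, only, none or still open, it means among the compounds named here.

Compound 1, `COc1ccc(F)cc1CNCCCNc1ccnc2cc(Oc3ccc(C(C)(C)C)cc3)ccc12`: 14500 nM
Compound 2, `COc1ccc(F)cc1CNCCCNc1ccnc2cc(Cc3ccc(F)cc3Cl)ccc12`: 4200 nM

In a physicochemical assay for solubility, with a stated time of 18 h, at pH 7.4 (a higher number here means a more soluble compound, a lower number a less soluble compound), compound 2 gives 4200 nM, the lowest of the two numbers; compound 1 is its nearest neighbour and differs by a 3.5-fold lower number from compound 1 to compound 2 (0.54 log units; beyond the scatter). Within the data shown here, compound 3, `COc1ccc(F)cc1CNCCCNc1ccnc2cc(-c3ccccc3)ccc12`, has not been measured. phenyl in place of 2-chloro-4-fluorobenzyl on an aromatic carbon The only measured step, a 3.5-fold lower number from compound 1 to compound 2 (0.54 log units; beyond the scatter), concerns a different group and bears on this change only loosely. Compound 3 is therefore expected to move by a 1.4-fold higher number from compound 2 to compound 3 (0.15 log units; within the scatter), a modest rise not clearly beyond the scatter. The estimate for compound 3 is 6000 nM, within 2000 nM to 18000 nM.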

Compound 3, solubility: 32000 nM
For compound 3 the middle estimate is 5.3-fold (0.73 log units) below the measured one, and the stated range ends below it.
By their numbers in this assay, from the lowest: compound 2; then compound 1; then compound 3.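

In this assay, phenyl in place of 2-chloro-4-fluorobenzyl on this aromatic carbon gives a 7.6-fold higher number from compound 2 to compound 3 (0.88 log units; beyond the scatter), so the number at this position can rise well past that of either earlier compound. Against the 4-(tert-butyl)phenoxy group, phenyl gives a 2.2-fold higher number from compound 1 to compound 3 (0.34 log units; beyond the scatter), which places this directly attached ring highest of the three, with both steps beyond the scatter. Nothing measured here accounts for these steps. As far as these compounds go, it remains open whether a phenyl carrying a single chlorine or fluorine would keep this number, and how an amine or a carboxylic acid on the same carbon would read.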